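Fluoro for Methyl: Cytotoxicity Before and After the Swap

The source may hold more compounds than are shown below. What is called first, only, known or untested is meant among the compounds shown, and "the series" means these compounds.

Of the compounds shown here, three have been tested in a functional assay on MT4 cells (Homo sapiens) for cytotoxicity, read by MTT assay, with a stated time of 5 days; on this read-out higher numbers stand for lower toxicity in this test and lower numbers for higher toxicity in this test. Compound 1 `N#Cc1ccc(Nc2nccc(Oc3ccc(-c4ccc(C#N)cc4Cl)cc3Cl)n2)cc1` reached only a limit of the assay, > 273000 nM. Compound 2 `COc1cc(-c2ccc(C#N)cc2)ccc1Oc1ccnc(Nc2ccc(C#N)cc2)n1` likewise reached only a limit, > 298000 nM. Within the data shown here, compound 3 `Cc1cc(-c2ccc(C#N)cc2)ccc1Nc1ccnc(Nc2ccc(C#N)cc2)n1` is the single compound with a measured number: in this assay compound 3 gives 9200 nM.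

Compound 4 `N#Cc1ccc(Nc2nccc(Nc3ccc(-c4ccc(C#N)cc4)cc3F)n2)cc1` has not yet been measured. It differs from compound 3 in one place: fluoro in place of methyl on an aromatic carbon. No measured pair of compounds differs in only one place, so the size of such a swap cannot be read from the numbers shown. One small group is exchanged for another small group of the same size, and no step beyond the usual scatter is expected in either direction. Compound 4 is therefore expected to give 11000 nM, with a range from 4000 nM to 40000 nM. The expected step, a 1.2-fold higher number from compound 3 to compound 4 (0.08 log units; within the scatter), is estimated to stay within the usual scatter.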

Compound 4, half-maximal cytotoxic concentration: 308000 nM
For compound 4 the middle estimate is 28-fold (1.45 log units) below the measured one, and the stated range ends below it.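

On an aromatic carbon ortho to a large group and meta to a 4-cyanophenyl group, fluoro in place of methyl gives a 33-fold higher number from compound 3 to compound 4 (1.52 log units; beyond the scatter) in this assay and so is far from a neutral exchange. This is the first pair shown that differs in only one place, and it reveals that exchanging one heavy atom for another at this position can move the read-out strongly, with no ring, charge or hydrogen-bond donor or acceptor counted on either group. Since a higher number stands for lower toxicity in this test, the methyl compound is the more toxic of this pair.

An ethyl or an amine at this position would help show whether the step follows the loss of methyl or the arrival of fluoro. Nothing in the data shown gives a reason for the step.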